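Shortening the nitrooxy ester chain

A few compounds are considered here, and "the series" means these few. Any claim that something is new, unique, unknown or untested is made for them only; others in the source may bear on it.

In a functional assay on HeLa cells (Homo sapiens) for cytotoxicity, read by resazurin assay, with a stated time of 72 h (a higher number here means a weaker inhibitor, a lower number a stronger inhibitor), compound 1 `COc1cc(/C=C/C(=O)OCCCCCCO[N+](=O)[O-])ccc1O` gives 16300 nM. That is the higher of the two actual numbers in the series. The other number belongs to compound 2 `O=C(/C=C/c1ccc(O)c(O)c1)OCc1c(-c2ccccc2)no[n+]1[O-]`, at 1230 nM, and the gap between the two lies beyond the usual scatter. Compound 3 `COc1cc(/C=C/C(=O)Oc2cccc(OCc3c(-c4ccccc4)no[n+]3[O-])c2)ccc1O` returns only a limit in this assay, > 50000 nM, and not a number.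

The next compound to be tested, compound 4 `COc1cc(/C=C/C(=O)OCCCO[N+](=O)[O-])ccc1O`, keeps the core of compound 1 and changes only the ester chain. Nitrooxy stands in place of 3-(nitrooxy)propyl on a saturated chain carbon, three bonds along the chain from an oxygen next to a carbonyl group (nitrooxy in place of 3-(nitrooxy)propyl on a saturated chain carbon, three bonds along the chain from an oxygen next to a carbonyl group).

Among the measured compounds shown here, no measured pair isolates this change, so the expectation has little support and stays wide. It rests on compound 1 at 16300 nM. In this assay no step beyond the scatter is expected, with a slight lean towards a higher number. The estimated change is a 1.3-fold higher number from compound 1 to compound 4 (0.13 log units; within the scatter), a small one. For compound 4 the expected value is 22000 nM, with an estimated range of 8000 nM to 60000 nM.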

Compound 4, half-maximal inhibitory concentration: 6700 nM
The estimate for compound 4 lay 3.3-fold (0.52 log units) above the measured number; the whole stated range lies above it.
By their numbers in this assay, from the lowest: compound 2; then compound 4; then compound 1. At a limit, above all of these: compound 3.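

Within the shared core of compound 1, the position on a saturated chain carbon, three bonds along the chain from an oxygen next to a carbonyl group, now has its first reading in one place: a 2.4-fold lower number from compound 1 to compound 4 (0.39 log units; beyond the scatter). Compound 4 keeps the nitrooxy group and the core of compound 1 and loses only chain carbons, so in this assay the length of the ester chain is not neutral, and the shorter chain goes with the lower number. Among the compounds shown here, compounds 2 and 3 differ from compound 1 in more than one place and could not show this, but the new step links only two chain lengths, so it gives a direction for this pair and not a trend.

Still open, going by these compounds, is whether the number keeps falling with a shorter chain, and whether the nitrooxy group is needed at all, which an ester chain ending in a hydroxyl group or a plain methyl group would test. Compound 3 gives only a limit in this assay and not a number, so it adds nothing to this reading: the limit of > 50000 nM in this assay, at which 1 of the 4 values shown sits.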